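Benzyl to tert-butyl on the nitrone nitrogen: an expectation

The source may hold more compounds than are shown below. What is called first, only, known or untested is meant among the compounds shown, and "the series" means these compounds.

Compound 1, `[O-]/[N+](=C\c1cn(-c2ccc(F)cc2)nn1)Cc1ccccc1`, in a functional assay on COLO 205 cells (Homo sapiens) for inhibition, read by MTT assay, with a stated time of 24 h (on this read-out higher numbers stand for weaker inhibition and lower numbers for stronger inhibition), gives a limit of the assay, > 100000 nM.
Compound 2, `COc1ccc(-n2cc(/C=[N+](\[O-])Cc3ccccc3)nn2)cc1`, in this assay gives a limit of the assay, > 100000 nM.
Compound 3, `[O-]/[N+](=C\c1cn(-c2ccc(C(F)(F)F)cc2)nn1)Cc1ccccc1`, in this assay gives a limit of the assay, > 100000 nM.

Compound 2 thus stands at a limit rather than at a number, and so does the whole measured set: the limit of > 100000 nM in this assay, at which 3 of the 3 values shown sit. Among the compounds with values here, the three measured steps, a step that the two limits leave unreadable from compound 1 to compound 2, a step that the two limits leave unreadable from compound 1 to compound 3 and a step that the two limits leave unreadable from compound 2 to compound 3, are unreadable in size; each joins two values that sit at the limit, so they show only that swapping one group on the aromatic carbon leaves every compound beyond the reach of this assay.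

Compound 4, `COc1ccc(-n2cc(/C=[N+](\[O-])C(C)(C)C)nn2)cc1`, differs from compound 2 at another place: tert-butyl in place of benzyl on a double-bonded nitrogen. Within the data shown here, no measured step touches this position, and the only guide is that compound 2 sits at the limit. Compound 4 is therefore expected to remain at or near that limit, with an expected step that the limit leaves unreadable from compound 2 to compound 4. For compound 4 the estimate is 200000 nM, with an expected range from 50000 nM to 1000000 nM.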

Compound 4, half-maximal inhibitory concentration: 19800 nM
Compound 4: middle estimate off by 10-fold (1.00 log units), on the high side, and the stated range ends above it.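

Unlike the swaps on the aromatic carbon, whose steps cannot be read, replacing benzyl with tert-butyl on the double-bonded nitrogen gives a step that can be read in this assay: there is an at least 5.0-fold lower number from compound 2 to compound 4 (0.70 log units; beyond the scatter). Among the compounds shown, this is the only change that brings a compound within the measurable range, so the group at this place matters more here than the group on the aromatic carbon. The true size of the step could be larger, because compound 2 has only a limit and not a number: the limit of > 100000 nM in this assay, at which 3 of the 4 values shown sit.

As far as these compounds go, only tert-butyl and benzyl appear on this nitrogen, so it remains open how an isopropyl or a cyclohexyl group would behave there. From the compounds shown here alone, it is also open whether fluoro or trifluoromethyl on the aromatic carbon would shift the number once tert-butyl is in place.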